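A few compounds are considered here, and "the series" means these few. Any claim that something is new, unique, unknown or untested is made for them only; others in the source may bear on it.

Of the compounds shown here, two with a shared core have been measured so far in a functional assay on HL-60 cells (Homo sapiens) for antiproliferative activity, read by sulforhodamine B assay, with a stated time of 72 h; a higher number here means a weaker inhibitor, a lower number a stronger inhibitor. Compound 1 `S=C(NCc1ccccc1)N/N=C/c1ccc2ccccc2n1` gives 21900 nM, and compound 2 `Cc1ccccc1NC(=S)N/N=C/c1ccc2ccccc2n1` gives 73200 nM, the higher of the two numbers, which makes compound 2 the weaker inhibitor of the pair. The next compound, compound 3 `S=C(N/N=C/c1ccc2ccccc2n1)Nc1ccccc1Br`, keeps compound 2 intact except for one group: bromo in place of methyl on an aromatic carbon. This group sits on a six-membered aromatic ring of carbon only, ortho to a large group, so the change reads 2-methylphenyl to 2-bromophenyl.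

Within the data shown here, no measured step makes this exact swap. Among the measured compounds shown here, the only step available, a 3.3-fold higher number from compound 1 to compound 2 (0.52 log units; beyond the scatter), put 2-methylphenyl in place of benzyl on an amide-type nitrogen, and it was modest but beyond the scatter. That step involves a different change, so it suggests no direction for this one. Given its modest size, a smaller shift is expected in this assay, probably within the scatter. The expected change is a 1.3-fold lower number from compound 2 to compound 3 (0.12 log units; within the scatter). The estimated value for compound 3 is 55000 nM, with an expected range from 20000 nM to 130000 nM.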

Compound 3, half-maximal inhibitory concentration: > 100000 nM
Compound 3: a limit, no number; the forecaster's own chance of this, stated with the estimate: 15%; middle value at least 1.8-fold (0.25 log units) away from the limit.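

In this assay the reading for compound 3 is a limit of the assay and not a number: the limit of > 100000 nM in this assay, at which 1 of the 3 values shown sits. On the ring carbon ortho to a large group, the change from 2-methylphenyl to 2-bromophenyl gives an at least 1.3-fold higher number from compound 2 to compound 3 (0.13 log units; that floor lies within the scatter), so the exchange brings no measurable gain in growth inhibition, but that floor does not by itself show bromo to be worse than methyl. The comparison with benzyl is firmer, with an at least 4.5-fold higher number from compound 1 to compound 3 (0.65 log units; beyond the scatter), so compound 1 is now the strongest inhibitor of the three, and both of the directly attached, ortho-substituted phenyl groups shown give weaker results than benzyl.

From the compounds shown here alone, without a number for compound 3, the true size of the gap between methyl and bromo at this position remains unknown. The compounds shown also leave open how fluoro, an amine or a carboxylic acid would behave on this ring carbon, and whether 2-phenylethyl, a longer chain than benzyl, would keep or improve on the result of compound 1.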